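The source may report more compounds than this note shows. Statements on the series, on what has been measured and on what is new or still open speak of the compounds shown alone.

The series consists of three measured compounds and one awaiting measurement. Compound 1 `O=c1cc(-c2ccccc2)oc2cccc(OCCCN3CCC(O)CC3)c12` gives 125 nM in an assay on isolated protein (Cavia porcellus) with Sigma non-opioid intracellular receptor 1 (Homo sapiens) as the target, read by radioligand binding; a lower number here means a stronger inhibitor, a higher number a weaker inhibitor. Compound 2 `O=c1cc(-c2ccccc2)oc2cccc(OCCCCN3CCC(O)CC3)c12` differs from it in one place, ((4-hydroxypiperidin-1-yl)methyl in place of 4-hydroxypiperidin-1-yl on a saturated chain carbon, three bonds along the chain from an oxygen on an aromatic ring), and in this assay compound 2 gives 58 nM, a step of a 2.2-fold lower number from compound 1 to compound 2 (0.33 log units; beyond the scatter). Compound 3 `O=c1cc(-c2ccccc2)oc2cc(OCCCCCCN3CCC(O)CC3)ccc12` is built on a core whose difference from the core of compound 1 is not broken down here; in this assay compound 3 gives 45 nM, which lies within the scatter of the value of compound 2 and beyond the scatter relative to compound 1. Compound 4 `O=c1cc(-c2ccccc2)oc2cc(OCCCCCCCN3CCC(O)CC3)ccc12` is not yet measured. It differs from compound 3 by (4-hydroxypiperidin-1-yl)methyl in place of 4-hydroxypiperidin-1-yl on a saturated chain carbon, six bonds along the chain from an oxygen on an aromatic ring. This is the same kind of change as that from compound 1 to compound 2, but it sits six bonds along the chain from the oxygen on the aromatic ring rather than three, and on a different core. Given the step of a 2.2-fold lower number from compound 1 to compound 2 (0.33 log units; beyond the scatter) and that compound 3 already sits at 45 nM, a smaller step is expected, a 1.3-fold lower number from compound 3 to compound 4 (0.11 log units; within the scatter), possibly within the scatter. Compound 4 is therefore estimated at 35 nM in this assay, with a likely range from 15 nM to 90 nM.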

Compound 4, half-maximal inhibitory concentration: 16 nM
Compound 4: the middle estimate sits 2.2-fold (0.34 log units) above what was measured; measured number inside the range.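

In this assay, (4-hydroxypiperidin-1-yl)methyl in place of 4-hydroxypiperidin-1-yl gives a 2.8-fold lower number from compound 3 to compound 4 (0.45 log units; beyond the scatter) on the second core. The change thus carries over from one core to the other, in the same direction and at a size that does not differ between the two: the same change on two cores in this assay, a 2.2-fold lower number (0.33 log units; beyond the scatter) from compound 1 to compound 2 and a 2.8-fold lower number (0.45 log units; beyond the scatter) from compound 3 to compound 4, 1.3-fold (0.12 log units) apart, within the scatter of two such steps

This agreement rests on two pairs alone, with the change six bonds along the chain from the oxygen on one core and three bonds along on the other, so it does not show that the step would hold on a further core or at another chain length, nor does it explain the step.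

The compounds shown leave open whether a longer chain, ending in 2-(4-hydroxypiperidin-1-yl)ethyl or 3-(4-hydroxypiperidin-1-yl)propyl in place of (4-hydroxypiperidin-1-yl)methyl, would lower the number further in this assay. As far as these compounds go, every compound carries the same hydroxyl-bearing ring at the chain end, so what a plain piperidine or a morpholine there would give is also open.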